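The compounds below may be only part of what the source reports. "The series", "measured", "known", "first", "only" and "open" are said of these compounds alone.

Working notes on the series. In a functional assay on ileum (Cavia porcellus) for antagonist activity (a higher number here means a weaker inhibitor, a lower number a stronger inhibitor), compound 1 `COc1ccc(OCCCOc2ccc3c(O)c([N+](=O)[O-])c(=O)oc3c2)cc1` returns only a limit, > 4000 nM. Compound 2 `CC(=O)c1ccc(OCCCOc2ccc3c(O)c([N+](=O)[O-])c(=O)oc3c2)cc1` reads 6100 nM, and compound 3 `Cc1ccc(OCCCOc2ccc3c(O)c([N+](=O)[O-])c(=O)oc3c2)cc1` reads 4500 nM. Neither step out of compound 1 can be sized: the series shows a step that the limit leaves unreadable from compound 1 to compound 2 and a step that the limit leaves unreadable from compound 1 to compound 3. Within the data shown here, the only readable step is a 1.4-fold lower number from compound 2 to compound 3 (0.13 log units; within the scatter).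

Compound 4 `Cc1ccccc1OCCCOc1ccc2c(O)c([N+](=O)[O-])c(=O)oc2c1` carries 2-methylphenyl in place of 4-methoxyphenyl on an oxygen on a saturated carbon. Among the measured compounds shown here, the nearest measured comparison is compound 3, which also has methyl in place of methoxy, but its step from compound 1 has no readable size, and no measured compound carries 2-methylphenyl.

No step beyond the scatter is expected in this assay, and no direction can be assigned, because a 1.4-fold lower number from compound 2 to compound 3 (0.13 log units; within the scatter) is the only size available. The expected value therefore stays close to compound 3 at 4500 nM and compound 2 at 6100 nM. For compound 4 there is a real chance that this assay again returns only a limit. The estimated change is a step that the limit leaves unreadable from compound 1 to compound 4. For compound 4 the expected value is 5000 nM, with an estimated range of 2500 nM to 10000 nM.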

Compound 4, half-maximal inhibitory concentration: 590 nM
Estimate against measurement, compound 4: 8.5-fold (0.93 log units) above; the measured number lies below the stated range.
By their numbers in this assay, from the lowest: compound 4; then compounds 3 and 2 (each within the scatter of the next).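

In this assay, the group on this oxygen now shows a readable effect: 2-methylphenyl in place of 4-methylphenyl gives a 7.6-fold lower number from compound 3 to compound 4 (0.88 log units; beyond the scatter), so two groups with the same name apart from where the methyl stands are clearly separated. Among these compounds, the comparisons with the other two groups point the same way, with a 10-fold lower number from compound 2 to compound 4 (1.01 log units; beyond the scatter) and an at least 6.7-fold lower number from compound 1 to compound 4 (0.83 log units; beyond the scatter), whereas the only readable step among the earlier compounds stayed within the scatter. The step out of compound 1 gives only a minimum size, since compound 1 returns a limit and not a number: the limit of > 4000 nM in this assay, at which 1 of the 4 values shown sits.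

Still open, as far as these compounds go, is whether the lower number belongs to the methyl of 2-methylphenyl in particular, or would also appear with methoxy, chloro or acetyl in its place, and how an unsubstituted phenyl would read against compound 4. Also open, from the compounds shown here alone, is whether the step from 4-methylphenyl to 2-methylphenyl would keep its size on a longer chain, or with an amine in place of the methyl.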